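The source may hold more compounds than are shown below. What is called first, only, known or untested is meant among the compounds shown, and "the series" means these compounds.

Compound 3 `COc1cc2ncnc(-n3nc(-c4ccccn4)nc3N)c2cc1OCCCNC(=O)CN1C[C@@H](C)O[C@@H](C)C1` shares its core with two other compounds tested for cytotoxicity. In an ADME assay on BJ cells (Homo sapiens) for cytotoxicity, with a stated time of 72 h (a higher number here means that more compound is needed for the effect, a lower number that less compound is needed), compound 3 gives no number but only a limit, > 25000 nM. Compound 1 `COc1cc2ncnc(-n3nc(-c4ccccn4)nc3N)c2cc1OCCCN(C)C` likewise reaches only a limit in this assay, > 25000 nM. Compound 2 `COCCOc1cc2c(-n3nc(-c4ccccn4)nc3N)ncnc2cc1OC` also stops at a limit in this assay, > 13000 nM. With the limit of > 25000 nM in this assay, at which 2 of the 3 values shown sit, and (the limit of > 13000 nM in this assay, at which 1 of the 3 values shown sits), compound 3 cannot be ranked against the others; all three sit at the edge of what this assay reports.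

Compound 4 `CCOC(=O)NCCCOc1cc2c(-n3nc(-c4ccccn4)nc3N)ncnc2cc1OC` differs from compound 3 at the carbonyl: ethoxy in place of (2,6-dimethylmorpholin-4-yl)methyl on a carbonyl carbon. The two measured steps that touch the same side chain, a step that the two limits leave unreadable from compound 1 to compound 2 and a step that the two limits leave unreadable from compound 1 to compound 3, both change the chain end, and neither is readable, so they give no size to carry over. Within the data shown here, no step expected in this assay can therefore be read as a direction, and compound 4 is expected to stay at a limit, with a number no higher from compound 3 to compound 4 (the limit leaves the size open) meaning no readable change. Compound 4 is estimated at 25000 nM in this assay, from 13000 nM to 50000 nM.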

Compound 4, half-maximal effective concentration: > 11000 nM
Compound 4 was reported as a limit; the forecaster's own chance of this, stated with the estimate: 85%; the middle value lies beyond the limit too.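

In this assay compound 4 gives only a limit, > 11000 nM. Its steps from compound 1, compound 2 and compound 3 cannot be read, since those values are limits too. The compounds shown leave open whether these different chain ends change cytotoxicity at all.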